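A few compounds are considered here, and "the series" means these few. Any claim that something is new, unique, unknown or untested is made for them only; others in the source may bear on it.

Values in a functional assay on BXPC-3 cells (Homo sapiens) for inhibition, read by MTT assay, with a stated time of 72 h; on this read-out lower numbers stand for stronger inhibition of growth and higher numbers for weaker inhibition of growth:
compound 1 `O=S(=O)(NCCNCc1cccc2ccccc12)c1cc(C(F)(F)F)cc(C(F)(F)F)c1`: 23000 nM
compound 2 `O=S(=O)(NCCCNCc1ccc(Cl)c(Cl)c1)c1cc(C(F)(F)F)cc(C(F)(F)F)c1`: 1400 nM

Going by the values given here, compound 2 stands at the lower of the two numbers in this assay; the only neighbour is compound 1, whose number lies well beyond the scatter on the weaker side. The two differ in more than one place, so their gap cannot be assigned to any single change.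

Compound 3 `O=S(=O)(NCCCNCc1ccccc1)c1cc(C(F)(F)F)cc(C(F)(F)F)c1` is the next member, differing from compound 2 by phenyl in place of 3,4-dichlorophenyl on a saturated chain carbon bound to an amine nitrogen. Among the compounds with values here, no pair of measured compounds isolates this change, and compound 1 offers no guidance on it. Working expectation: the step is most likely toward weaker inhibition of growth, of moderate size and probably beyond the scatter, though a result within the scatter cannot be ruled out; the expected step reads a 3.6-fold higher number from compound 2 to compound 3 (0.55 log units; beyond the scatter). Compound 3 is estimated at 5000 nM, within a range from 1500 nM to 20000 nM.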

Compound 3, concentration for 50% growth inhibition: 13000 nM
Compound 3: middle estimate off by 2.6-fold (0.41 log units), on the low side, and the stated range covers the measured number.
By their numbers in this assay, from the lowest: compound 2; then compounds 3 and 1 (each within the scatter of the next).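

With the rest of the molecule held constant, phenyl in place of 3,4-dichlorophenyl on a saturated chain carbon bound to an amine nitrogen gives a 9.3-fold higher number from compound 2 to compound 3 (0.97 log units; beyond the scatter) in this assay. Going by these compounds alone, this is the first single-place comparison, and it shows that inhibition of growth at this position responds to the aryl group, with the stronger inhibition going with 3,4-dichlorophenyl in this one pair. No measured property bears on the size of this step.

Whether one chlorine alone accounts for the step remains open, as does the outcome with 3-chlorophenyl, 4-chlorophenyl or 4-methoxyphenyl in the same place. Compound 1 still differs from compound 2 and compound 3 in more than one place, so its contribution cannot be assigned to any single change.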